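This account rests on a few compounds, and the source may have more. Where it says the series, first, only, none or still open, it means among the compounds named here.

Measured in a physicochemical assay for lipophilicity, read by HPLC, measured as chromatographic lipophilicity, at pH 7.4 (on this read-out higher numbers stand for higher lipophilicity and lower numbers for lower lipophilicity), so far:
Compound 1 `CC(=O)N1CCC(C(=O)N2N=CCC2c2ccccc2)CC1` gives 2.5
Compound 2 `CN1CCC(C(=O)N2N=CCC2c2ccccc2)CC1` gives 1.1

Compound 2 is the lower of the two, at 1.1 on this scale. Compound 3 `O=C(c1cocn1)N1CCC(C(=O)N2N=CCC2c2ccccc2)CC1` differs from it by (1,3-oxazol-4-yl)carbonyl in place of methyl on an amine nitrogen in a ring and so has (1,3-oxazol-4-yl)carbonyl in place of methyl on an amine nitrogen in a ring. Within the data shown here, one measured step bears on this, and it is large: a number 1.40 log units lower from compound 1 to compound 2 (beyond the scatter) with methyl in place of acetyl on that nitrogen. Among the measured compounds shown here, compound 3 carries a carbonyl there, as compound 1 does, but no compound with this exact group has been measured. A rise of similar size is therefore expected in this assay from compound 2. The estimated step is a number 1.50 log units higher from compound 2 to compound 3 (beyond the scatter) in size. For compound 3 the expected value is 2.6 with an estimated range from 2.2 to 3 around it.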

Compound 3, distribution coefficient: 2.9
The estimate for compound 3 lay 0.30 log units below the measured number, within the range that was stated.
By their numbers in this assay, from the lowest: compound 2; then compound 1; then compound 3.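

In this assay, a second carbonyl-bearing group on this amine nitrogen also stands far above methyl, a number 1.80 log units higher from compound 2 to compound 3 (beyond the scatter), so the large gap is not confined to acetyl. What sits on the carbonyl carbon matters too, since 1,3-oxazol-4-yl in place of methyl gives a smaller but real change, a number 0.40 log units higher from compound 1 to compound 3 (beyond the scatter). Nothing at hand accounts for either step. The compounds shown leave open whether a phenyl ring or a longer chain such as propyl on that carbonyl carbon would give a similar step. They also leave open whether a sulfonyl group on the amine nitrogen would match the carbonyl groups.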